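Swapping a Para Chloro for Amino on the Aryl Arm

A few compounds are considered here, and "the series" means these few. Any claim that something is new, unique, unknown or untested is made for them only; others in the source may bear on it.

Measured so far:
- Compound 1, `CC(C)(C)n1cc2c(n1)C(=O)CC1(CCN(C(=O)c3cc(-c4ccc(Cl)cc4)nc4ccccc34)CC1)O2`: 630 nM
- Compound 2, `CC(C)(C)n1cc2c(n1)C(=O)CC1(CCN(C(=O)c3cc(-c4ccc(F)cc4)nc4ccccc34)CC1)O2`: 2930 nM

Both compounds were tested in a functional assay on HepG2 cells (Homo sapiens) for inhibition, read by MTT assay, with a stated time of 72 h; a lower number here means a stronger inhibitor, a higher number a weaker inhibitor. Among the measured compounds shown here, compound 1 has the lowest number of the two, and compound 2 sits a 4.7-fold higher number from compound 1 to compound 2 (0.67 log units; beyond the scatter) away from it, the only measured step in this set.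

Compound 3, `CC(C)(C)n1cc2c(n1)C(=O)CC1(CCN(C(=O)c3cc(-c4ccc(N)cc4)nc4ccccc34)CC1)O2`, is the unmeasured compound. It differs from compound 1 by amino in place of chloro on an aromatic carbon. For the measured compounds named here, no measured pair shows this exact exchange. Going by the values given here, the one related step is the replacement of the same chloro by fluoro, a 4.7-fold higher number from compound 1 to compound 2 (0.67 log units; beyond the scatter), which weakened inhibition beyond the scatter. Since the change to compound 3 also removes the chloro and puts a different one-atom group in its place, a weakening of at least similar size is expected, a 5.6-fold higher number from compound 1 to compound 3 (0.74 log units; beyond the scatter). For compound 3 the estimated value in this assay is 3500 nM, within a range of 1000 nM to 12000 nM.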

Compound 3, half-maximal inhibitory concentration: 630 nM
The estimate for compound 3 lay 5.6-fold (0.74 log units) above the measured number; measured number below the stated range.
By their numbers in this assay, from the lowest: compounds 1 and 3 (each within the scatter of the next); then compound 2.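

In this assay, the chloro is not needed for the lower number at this position, since putting amino in its place gives no change at the digits printed from compound 1 to compound 3 (within the scatter). The earlier pair made it look as if losing the chloro itself weakened inhibition, but amino in place of fluoro gives a 4.7-fold lower number from compound 2 to compound 3 (0.67 log units; beyond the scatter), so the outcome depends on which group enters and not simply on the chloro leaving. Nothing available here explains why fluoro parts from the other two groups at this position.

Still open, from the compounds shown here alone, is how other groups at this position, such as methoxy, a carboxylic acid or a longer chain on the amino nitrogen, would compare with these three. Going by these compounds, whether the same order would hold in other cell types also remains open.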